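The source may hold more compounds than are shown below. What is called first, only, known or untested is meant among the compounds shown, and "the series" means these compounds.

Measured so far:
Compound 1, `COc1nc2ccc(Br)cc2cc1C(c1ccccc1)n1cc(CCO)nn1`: in an ADME assay on HEK293 cells (Homo sapiens) for cytotoxicity, read by sulforhodamine B assay, with a stated time of 48 h, tested at 10 uM (a lower number here means less inhibition, a higher number more inhibition at the concentration tested (going by the name of the read-out)), compound 1 gives 4.54%.
Compound 2, `COc1nc2ccc(Br)cc2cc1C(c1ccccc1)n1cc(-c2ccc(F)cc2)nn1`: in this assay compound 2 gives 4.04%.

Going by the values given here, compound 2 stands at the lowest of the two numbers, and the only other compound, compound 1, sits within the usual scatter of it: a number 0.5 percentage points lower from compound 1 to compound 2 (within the scatter). Compound 3, `COc1nc2ccc(Br)cc2cc1C(c1ccccc1)n1cc(C2CC2)nn1`, has not been measured yet. It differs from compound 2 by one change on an aromatic carbon: cyclopropyl in place of 4-fluorophenyl on an aromatic carbon.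

Among the compounds with values here, only one measured step bears on this change, the exchange of 2-hydroxyethyl for 4-fluorophenyl on that aromatic carbon, which gave a number 0.5 percentage points lower from compound 1 to compound 2 (within the scatter). Within the data shown here, no step with cyclopropyl has been measured. Among the measured compounds shown here, since the one step at this position stayed inside the scatter, the step to compound 3 is expected to stay inside it as well: a number 1 percentage points higher from compound 2 to compound 3 (within the scatter). Compound 3 is therefore estimated at 5%, with a likely range from 0% to 15%.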

Compound 3, a percentage reported as inhibition, at one concentration (the size of the read-out at that concentration, not a potency): 8.22%
The estimate for compound 3 lay 3.2 percentage points below the measured number, within the range that was stated.
By their numbers in this assay, from the lowest: compounds 2, 1 and 3 (each within the scatter of the next).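

In this assay, cyclopropyl in place of 4-fluorophenyl gives a number 4.2 percentage points higher from compound 2 to compound 3 (within the scatter) and thus adds a non-aromatic, three-membered carbon ring to the groups tested on this aromatic carbon. Set against the chain of compound 1, cyclopropyl gives a number 3.7 percentage points higher from compound 1 to compound 3 (within the scatter) and so, on these numbers, the three groups cannot be told apart at this position, despite their different ring types and sizes. No measurement at hand offers an explanation for these numbers.

Still open, going by these compounds, is whether an amine, a carboxylic acid or a longer chain on this carbon would also stay within the scatter. All three compounds share the same core, so they also leave open what a change elsewhere would do, such as replacing the bromine with a nitrile.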